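The source may report more compounds than this note shows. Statements on the series, on what has been measured and on what is new or still open speak of the compounds shown alone.

In a functional assay on MDA-MB-231 cells (Homo sapiens) for antiproliferative activity, read by MTT assay, with a stated time of 72 h (on this read-out higher numbers stand for weaker inhibition and lower numbers for stronger inhibition), compound 1 `O=C(CCc1cccc2c1B(O)OC2)NC1CCCCC1` reads > 100000 nM, which is a limit of the assay and not a number. Compound 2 `O=C(CCc1cccc2c1B(O)OC2)NCc1ccccc1` reads > 100000 nM, which is also a limit. Within the data shown here, compound 2 therefore has no numerical position, and the series so far rests on (the limit of > 100000 nM in this assay, at which 2 of the 2 values shown sit). Compound 3 `Cc1ccc(NC(=O)CCc2cccc3c2B(O)OC3)cc1` differs from compound 2 by one change, (4-methylphenyl in place of benzyl on an amide-type nitrogen), with 4-methylphenyl in place of benzyl on an amide-type nitrogen. Among the measured compounds shown here, the only measured step at this place is a step that the two limits leave unreadable from compound 1 to compound 2, so it offers no size or direction to carry forward. No step beyond the usual scatter can be argued for in this assay, and compound 3 is expected to stay in the same region, quite possibly again at the limit. The estimated change is a number no higher from compound 2 to compound 3 (the limit leaves the size open). For compound 3 the expected value is 100000 nM, with an estimated range of 30000 nM to 200000 nM.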

Compound 3, half-maximal inhibitory concentration: 1100 nM
Beside the measured number, compound 3's estimate is 91-fold (1.96 log units) above it; measured number outside the range, below it.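

In this assay the group on the amide-type nitrogen proves able to separate a measurable compound from the limit: 4-methylphenyl in place of benzyl gives an at least 90-fold lower number from compound 2 to compound 3 (1.95 log units; beyond the scatter), and 4-methylphenyl in place of cyclohexyl gives an at least 90-fold lower number from compound 1 to compound 3 (1.95 log units; beyond the scatter). The first of these steps is notable in that the entering and leaving groups hold the same atoms, joined differently, so this place responds to the arrangement of those atoms and not only to their number. Compound 3 is the only compound here with a number, so the size of each step remains open-ended: the limit of > 100000 nM in this assay, at which 2 of the 3 values shown sit.

The compounds shown leave open whether plain phenyl, without the methyl, would keep this activity, or whether 4-chlorophenyl or 4-methoxyphenyl would read alike. They also leave open how a longer chain between the carbonyl and the shared core would read.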